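Swapping a Bromophenyl for a Furan Ring

The compounds below may be only part of what the source reports. "The series", "measured", "known", "first", "only" and "open" are said of these compounds alone.

Three measured compounds share one core and differ only in the aromatic group attached to a carbon with a double bond to nitrogen. Compound 1 `O=C(CSc1nnc(-c2ccncc2)o1)N/N=C/c1ccccc1` carries a plain phenyl; in a functional assay on SW 1116 cells (Homo sapiens) for cytotoxicity, read by MTT assay, with a stated time of 48 h (on this read-out lower numbers stand for stronger inhibition and higher numbers for weaker inhibition), compound 1 gives 16700 nM. Compound 2 `O=C(CSc1nnc(-c2ccncc2)o1)N/N=C/c1ccc(Br)cc1` carries a 4-bromophenyl, and in this assay compound 2 gives 21300 nM. Compound 3 `O=C(CSc1nnc(-c2ccncc2)o1)N/N=C/c1ccccc1[N+](=O)[O-]` carries a 2-nitrophenyl, and in this assay compound 3 gives 30700 nM. Compound 2 stands second highest of the three numbers, with compound 1 nearest and compound 3 furthest, both gaps inside the scatter. The step of a 1.4-fold higher number from compound 2 to compound 3 (0.16 log units; within the scatter) is the closest model for exchanging the aromatic group at this position, and a 1.3-fold higher number from compound 1 to compound 2 (0.11 log units; within the scatter) and a 1.8-fold higher number from compound 1 to compound 3 (0.26 log units; within the scatter) are just as small. The new compound 4 `O=C(CSc1nnc(-c2ccncc2)o1)N/N=C/c1ccco1` differs from compound 2 by furan-2-yl in place of 4-bromophenyl on a carbon with a double bond to nitrogen. With a 1.4-fold higher number from compound 2 to compound 3 (0.16 log units; within the scatter) as the nearest guide, compound 4 is expected to give 20000 nM, within a range from 9000 nM to 45000 nM. This estimate corresponds to an expected step of a 1.1-fold lower number from compound 2 to compound 4 (0.03 log units; within the scatter), no larger than the scatter.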

Compound 4, half-maximal inhibitory concentration: 18800 nM
Compound 4: middle estimate off by 1.1-fold (0.03 log units), on the high side; measured number inside the range.
By their numbers in this assay, from the lowest: compounds 1, 4, 2 and 3 (each within the scatter of the next).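

In this assay, going by these compounds alone, the furan-2-yl group is the first here that is not a substituted or plain phenyl: it brings a five-membered aromatic ring with a hetero atom and a hydrogen-bond acceptor, yet the step is small, with a 1.1-fold lower number from compound 2 to compound 4 (0.05 log units; within the scatter). The comparisons with the other two groups agree, giving a 1.1-fold higher number from compound 1 to compound 4 (0.05 log units; within the scatter) and a 1.6-fold lower number from compound 3 to compound 4 (0.21 log units; within the scatter). Among these four compounds, then, even a change in ring size and ring atoms on the carbon with a double bond to nitrogen does not move the number beyond the scatter.

No further data bear on why the numbers stay so close. As far as these compounds go, whether an amine, a carboxylic acid or a longer chain in this place would produce a step beyond the scatter remains open.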